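This account rests on a few compounds, and the source may have more. Where it says the series, first, only, none or still open, it means among the compounds named here.

Compound 1 `O=S(=O)(Nc1ccc(-c2nc3ccccc3o2)cc1)c1cccc(O)c1`: > 100000 nM (a limit)
Compound 2 `O=S(=O)(Nc1ccc(-c2nc3ccccc3o2)cc1)c1cccc(C(F)(F)F)c1`: > 100000 nM (a limit)
Compound 3 `COc1ccccc1S(=O)(=O)Nc1ccc(-c2nc3ccccc3o2)cc1`: > 100000 nM (a limit)

All three compounds were tested in an ADME assay on HEK293 cells (Homo sapiens) for cytotoxicity, read by resazurin assay, with a stated time of 48 h (a lower number here means that less compound is tolerated, a higher number that more compound is tolerated), and none of them gave a number. Compound 3 stands at > 100000 nM, which is a limit. It shares that position with the other two, so the whole set sits at the limit of > 100000 nM in this assay, at which 3 of the 3 values shown sit.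

The unmeasured compound 4 `COc1cccc(S(=O)(=O)Nc2ccc(-c3nc4ccccc4o3)cc2)c1` has the same atoms as compound 3, joined differently: 3-methoxyphenyl in place of 2-methoxyphenyl on a sulfonyl sulfur. In words, 3-methoxyphenyl replaces 2-methoxyphenyl on a sulfonyl sulfur.

Two measured changes bear on this. The closer one is a step that the two limits leave unreadable from compound 1 to compound 3, which puts 2-methoxyphenyl in place of 3-hydroxyphenyl on a sulfonyl sulfur. The other is a step that the two limits leave unreadable from compound 1 to compound 2, which puts trifluoromethyl in place of hydroxy on an aromatic carbon. Neither has a readable size, so neither offers a measured shift to carry over. Still, all three compounds remain at the limit, and no step beyond the scatter is expected in this assay, in either direction. The expected change is a number no higher from compound 3 to compound 4 (the limit leaves the size open). A report as a limit alone is the most likely outcome. For compound 4 the estimated value is 100000 nM, with an expected range from 50000 nM to 200000 nM.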

Compound 4, half-maximal cytotoxic concentration: > 100000 nM
Compound 4 gave a limit, no number; the forecaster's own chance of this, stated with the estimate: 85%; the middle value sits exactly at the limit.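

The result for compound 4 is also a limit, so the steps to compound 4 from compound 1, compound 2 and compound 3 cannot be read, and no new step emerges: the limit of > 100000 nM in this assay, at which 4 of the 4 values shown sit.

The compounds shown leave open whether any of these changes on the sulfonyl sulfur alters the tolerated concentration in this assay.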